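The source may hold more compounds than are shown below. What is called first, only, known or untested is meant among the compounds shown, and "the series" means these compounds.

In a functional assay on A549 cells (Homo sapiens) for inhibition, read by MTT assay, with a stated time of 48 h (a lower number here means a stronger inhibitor, a higher number a weaker inhibitor), compound 1 (`COc1ccc2c(=O)c(/C=C/C(=O)Nc3cccc(Cl)c3)coc2c1`), with 3-chlorophenyl on the amide-type nitrogen, gives 470 nM. Compound 2 (`COc1ccc(NC(=O)/C=C/c2coc3cc(OC)ccc3c2=O)cc1`) gives 23000 nM, and compound 3 (`COc1ccc2c(=O)c(/C=C/C(=O)Nc3ccc(F)cc3)coc2c1`) gives 26800 nM. Compound 3 therefore stands level with compound 2, with a 1.2-fold higher number from compound 2 to compound 3 (0.07 log units; within the scatter), and far from compound 1, with a 57-fold higher number from compound 1 to compound 3 (1.76 log units; beyond the scatter). The companion change shows a 49-fold higher number from compound 1 to compound 2 (1.69 log units; beyond the scatter).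

Compound 4 (`COc1ccc2c(=O)c(/C=C/C(=O)NCc3ccc(F)cc3F)coc2c1`) is altered at that same nitrogen: 2,4-difluorobenzyl in place of 4-fluorophenyl on an amide-type nitrogen. In words, 2,4-difluorobenzyl takes the place of 4-fluorophenyl. Among the compounds with values here, the large steps show that this position can matter, but they involve only phenyl groups, and no measured compound carries 2,4-difluorobenzyl. Their guidance is therefore indirect. The only measured departure from the level of compound 3 runs towards a lower number, in compound 1 at 470 nM, so a modest shift in that direction is expected, far smaller than those large steps. The expected step is a 2.2-fold lower number from compound 3 to compound 4 (0.35 log units; beyond the scatter). Compound 4 is estimated at 12000 nM, with an expected range from 2500 nM to 45000 nM.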

Compound 4, half-maximal inhibitory concentration: 13300 nM
Compound 4: the middle estimate sits 1.1-fold (0.04 log units) below what was measured; low and high end bracket the measured number.
By their numbers in this assay, from the lowest: compound 1; then compounds 4, 2 and 3 (each within the scatter of the next).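

In this assay, within the data shown here, 2,4-difluorobenzyl is the only group on the amide-type nitrogen that is not a phenyl group, and the change away from phenyl does not by itself set compound 4 apart: a 2.0-fold lower number from compound 3 to compound 4 (0.30 log units; within the scatter) and a 1.7-fold lower number from compound 2 to compound 4 (0.24 log units; within the scatter) are both small steps. The large gap therefore no longer separates only phenyl groups from one another, since a 28-fold higher number from compound 1 to compound 4 (1.45 log units; beyond the scatter) places 3-chlorophenyl well apart from 2,4-difluorobenzyl as well. Nothing measured here explains why compound 1 alone stands apart.

The compounds shown leave open whether a benzyl group carrying chlorine would reach the level of compound 1. They also leave open whether phenylethyl, a longer chain, or cyclohexyl on the same nitrogen would stay level with compounds 2, 3 and 4.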